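A few compounds are considered here, and "the series" means these few. Any claim that something is new, unique, unknown or untested is made for them only; others in the source may bear on it.

Measured so far in an ADME assay on 184B5 cells (Homo sapiens) for antiproliferative activity, read by sulforhodamine B assay, with a stated time of 72 h; a higher number here means a weaker inhibitor, a lower number a stronger inhibitor:
- Compound 1 `COc1ccc2nc(Cl)c(/C=C/c3ccc(C(F)(F)F)cc3)cc2c1`: 33500 nM
- Compound 2 `COc1ccc2nc(Cl)c(/C=C\c3ccc(F)cc3)cc2c1`: 19200 nM

Only these two compounds have numbers, and compound 2, at 19200 nM, cannot be ranked against compound 1, at 33500 nM, since the two values lie within the usual scatter of repeated measurements. Both values can be taken as one level, and compound 2 is the starting point here.

The next compound is compound 3 `COc1ccc2nc(Cl)c(/C=C/c3ccc(F)cc3)cc2c1`. Its change from compound 2 is unusually small: the two compounds have the same atoms and bonds and differ only in configuration as drawn: 1 of 1 stereo elements differ; a double bond is drawn Z in compound 2 and E in compound 3. Nothing leaves and nothing enters, and the same atoms and bonds remain. A double bond is simply drawn Z in compound 2 and E in compound 3.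

Among the compounds with values here, no measured pair in this assay shows what a change of this kind does, so the data offer no direct guide to its size or direction. The plain expectation is therefore no shift beyond the scatter, with a wide margin for surprise. The expected step is a 1.1-fold higher number from compound 2 to compound 3 (0.06 log units; within the scatter). For compound 3 the estimated value is 22000 nM, with an expected range of 9000 nM to 50000 nM.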

Compound 3, half-maximal inhibitory concentration: 9740 nM
For compound 3 the middle estimate is 2.3-fold (0.35 log units) above the measured one; measured number inside the range.
By their numbers in this assay, from the lowest: compounds 3, 2 and 1 (each within the scatter of the next, the first and the last beyond it).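

In this assay, within the data shown here, compounds 2 and 3 give the first direct look at the geometry of the double bond, and the result is a 2.0-fold lower number from compound 2 to compound 3 (0.29 log units; within the scatter), so the Z and E forms cannot be told apart on this evidence. This pair is a clean test of that one feature, and the reading rests on a single point: the fact that compounds 2 and 3 differ only in the configuration as drawn. The second new comparison keeps the double bond drawn E and changes the group on the aromatic carbon, with fluoro in place of trifluoromethyl, giving a 3.4-fold lower number from compound 1 to compound 3 (0.54 log units; beyond the scatter), a modest step and the first here to lie beyond the scatter.

Still open is whether another group on that aromatic carbon, such as an amine or a carboxylic acid, would move the number further, and whether the step from trifluoromethyl to fluoro would hold with the double bond drawn Z. The compounds shown also leave open what happens when the double bond gives way to a longer saturated chain, or when the chloro or methoxy group on the shared core is replaced.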